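Chloroanilide thioester series: growth inhibition notes

A few compounds are considered here, and "the series" means these few. Any claim that something is new, unique, unknown or untested is made for them only; others in the source may bear on it.

Measured compounds:
compound 1 `CC(=O)SCCC(CCCCC(=O)Nc1cccc(Cl)c1)SC(C)=O`: 0.56%
compound 2 `CC(=O)SCCC(CCCCC(=O)Nc1ccc(Cl)cc1)SC(C)=O`: 3.07%
compound 3 `O=C(CCCCC(CCSC(=O)c1ccccc1)SC(=O)c1ccccc1)Nc1cccc(Cl)c1`: "not active" (no number reported)

In a functional assay on Bel-7402 cells (Homo sapiens) for inhibition, read by MTT assay, with a stated time of 24 h, tested at 1 ug/mL (on this read-out higher numbers stand for more inhibition of growth at the one concentration tested and lower numbers for less inhibition of growth), compound 1 gives 0.56% and compound 2 gives 3.07%. The change between them is 4-chlorophenyl in place of 3-chlorophenyl on an amide-type nitrogen; it made a step of a number 2.5 percentage points higher from compound 1 to compound 2 (within the scatter). Compound 3 is reported as "not active" (no number reported) in this assay, without a number. The difference between the core of compound 1 and the core of compound 3 is not broken down here. Compound 4 `O=C(CCCCC(CCSC(=O)c1ccccc1)SC(=O)c1ccccc1)Nc1ccc(Cl)cc1` differs from compound 3 by 4-chlorophenyl in place of 3-chlorophenyl on an amide-type nitrogen, the same change as in the pair already measured. The step from compound 3 to compound 4 is expected to be small, of the kind seen in a number 2.5 percentage points higher from compound 1 to compound 2 (within the scatter). Compound 4 is therefore expected near 2% in this assay, between -8% and 12%, with a real chance that only "not active" is reported.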

Compound 4, percent growth inhibition at one concentration: 9.62%
Compound 4: middle estimate off by 7.6 percentage points, on the low side; the measured number falls inside the stated range.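

No step can be read between compound 3 and compound 4: compound 3 is reported as "not active", without a number. The compounds shown leave open how the core of compound 3 compares with the core of compound 1. No supporting evidence bears on this result.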